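Methoxy pattern change on the shared core

The source may hold more compounds than are shown below. What is called first, only, known or untested is meant among the compounds shown, and "the series" means these compounds.

Two compounds are in hand. Compound 1 `COc1cc(Nc2nc3ccccc3nc2S(=O)(=O)c2ccc(Br)cc2)cc(OC)c1` gives 15900 nM in a functional assay on A549 cells (Homo sapiens) for cytotoxicity, read by MTT assay, with a stated time of 72 h; on this read-out higher numbers stand for weaker inhibition and lower numbers for stronger inhibition; compound 2 `COc1ccc(Nc2nc3ccccc3nc2S(=O)(=O)c2ccc(F)cc2)cc1` gives 4840 nM, the lowest of the two numbers, and compound 1 stands a step beyond the scatter above it. Compound 3 `COc1cc(Nc2nc3ccccc3nc2S(=O)(=O)c2ccc(F)cc2)cc(OC)c1` is not yet measured. It differs from compound 2 by 3,5-dimethoxyphenyl in place of 4-methoxyphenyl on a nitrogen on an aromatic ring. Among the compounds with values here, no single-change pair covers this switch, so the expectation leans on compound 1, which also carries the 3,5-dimethoxyphenyl and gives 15900 nM. A step toward a higher number, beyond the scatter, is expected: a 2.1-fold higher number from compound 2 to compound 3 (0.32 log units; beyond the scatter). For compound 3 the estimate is 10000 nM, within 3500 nM to 28000 nM.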

Compound 3, half-maximal inhibitory concentration: 5450 nM
The estimate for compound 3 lay 1.8-fold (0.26 log units) above the measured number; measured number inside the range.
By their numbers in this assay, from the lowest: compounds 2 and 3 (each within the scatter of the next); then compound 1.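

In this assay, 3,5-dimethoxyphenyl in place of 4-methoxyphenyl on a nitrogen on an aromatic ring comes with a 1.1-fold higher number from compound 2 to compound 3 (0.05 log units; within the scatter), so the methoxy pattern alone does not separate these two compounds. The high number of compound 1 goes instead with the halogen: fluoro in place of bromo on an aromatic carbon comes with a 2.9-fold lower number from compound 1 to compound 3 (0.47 log units; beyond the scatter).

No measured property bears on either step, so neither can be explained. Still open, as far as these compounds go, is whether an amine or a carboxylic acid on the ring at that nitrogen would move the number, and whether the bromo step holds with 4-methoxyphenyl.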